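A few compounds are considered here, and "the series" means these few. Any claim that something is new, unique, unknown or untested is made for them only; others in the source may bear on it.

Working notes on the series, read in an ADME assay on microsomes from liver (Rattus norvegicus) for metabolic stability; a higher number here means that the compound lasts longer, a lower number that the compound disappears faster. Compound 1 `CS(=O)(=O)N1CCN(CC(O)CN2CCC(CNC(=O)c3cccc4[nH]c(C5CC5)nc34)CC2)CC1` gives > 1.5 h, which is a limit of the assay and not a number. Compound 2 `COC(=O)N1CCN(CCN2CCC(CNC(=O)c3cccc4[nH]c(C(C)C)nc34)CC2)CC1` gives > 1.5 h, also a limit and not a number. Among the compounds with values here, compound 2 therefore has no exact value and stands with the only other measured compound at the limit of > 1.5 h in this assay, at which 2 of the 2 values shown sit.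

Compound 3 `CC(=O)N1CCC(CN2CCC(CNC(=O)c3cccc4[nH]c(C(C)C)nc34)CC2)CC1` differs from compound 2 as follows: 1-acetylpiperidin-4-yl in place of (4-(methoxycarbonyl)piperazin-1-yl)methyl on a saturated chain carbon bound to an amine nitrogen in a ring. It has 1-acetylpiperidin-4-yl in place of (4-(methoxycarbonyl)piperazin-1-yl)methyl on a saturated chain carbon bound to an amine nitrogen in a ring.

Within the data shown here, no measured step in this assay shows the effect of such a change, so no shift beyond the scatter is expected in either direction. The expected change is a number no higher from compound 2 to compound 3 (the limit leaves the size open). For compound 3 the estimated half-life is 1.5 h, with an expected range of 0.7 h to 3 h.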

Compound 3, half-life: > 1.5 h
Compound 3 was reported as a limit (the forecaster's own chance of this, stated with the estimate: 70%); the middle value sits exactly at the limit.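

Compound 2 and compound 3 are both reported only as limits of the assay, not as numbers, so no step between them can be read in this assay: the limit of > 1.5 h in this assay, at which 3 of the 3 values shown sit.

The compounds shown leave open the actual half-lives of all three compounds, and whether 1-acetylpiperidin-4-yl in place of (4-(methoxycarbonyl)piperazin-1-yl)methyl changes the half-life at all.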